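The compounds below may be only part of what the source reports. "The series", "measured", "known", "first", "only" and "open" are said of these compounds alone.

Measured so far in an ADME assay on RAW264.7 cells (Mus musculus) for cytotoxicity, read by MTT assay, with a stated time of 48 h; on this read-out lower numbers stand for higher toxicity in this test and higher numbers for lower toxicity in this test:
- compound 1 `CC(=O)OC[C@H]1O[C@H](OC[C@H](Cn2cc(COc3ccc(-c4noc(NC5CCCCC5)n4)cc3)nn2)OC(C)=O)C=C[C@@H]1OC(C)=O`: 33.3 ug/mL
- compound 2 `C#Cc1ccc(-c2noc(NC3CCCCC3)n2)cc1`: 19.8 ug/mL

Two compounds have numbers in this assay. Compound 1 stands at the upper end of the pair, but its gap to compound 2 lies within the usual scatter, so the two are not separated by these data. Compound 2 shares the cyclohexylamino-bearing core of compound 1 while lacking the sugar-triazole part.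

Compound 3 `CC(=O)OC[C@H]1O[C@H](OC[C@H](Cn2cc(COc3ccc(-c4noc(C)n4)cc3)nn2)OC(C)=O)C=C[C@@H]1OC(C)=O` differs from compound 1 in one place: methyl in place of cyclohexylamino on an aromatic carbon. For the measured compounds named here, no measured pair follows this change, so there is no step to lean on; the only related comparison, compound 1 against compound 2, shows that a sizeable change elsewhere left the number within the scatter. On that basis the step of a 1.1-fold higher number from compound 1 to compound 3 (0.02 log units; within the scatter) is expected to be small, without a clear direction beyond the scatter. For compound 3 in this assay the estimate is 35 ug/mL, with a range from 15 ug/mL to 80 ug/mL.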

Compound 3, half-maximal cytotoxic concentration: 112 ug/mL
Estimate against measurement, compound 3: 3.2-fold (0.51 log units) below; measured number above the stated range.
By their numbers in this assay, from the lowest: compounds 2 and 1 (each within the scatter of the next); then compound 3.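

In this assay, for the compounds shown here, going from 5-(cyclohexylamino)-1,2,4-oxadiazol-3-yl to 5-methyl-1,2,4-oxadiazol-3-yl gives a 3.4-fold higher number from compound 1 to compound 3 (0.53 log units; beyond the scatter), the first step read beyond the scatter. The group on this aromatic carbon therefore affects the read-out, and here methyl goes with lower toxicity in this test than cyclohexylamino. The change removes the six-membered carbon ring and the hydrogen-bond donor together, and no measurement at hand accounts for the step.

With only these two groups at this position, the ring and the amine hydrogen cannot be told apart; a cyclohexyl or a dimethylamino group on the same carbon would separate them. Also open, from the compounds shown here alone, is whether an ethyl or a propyl group would stay close to methyl or move back toward cyclohexylamino.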